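A few compounds are considered here, and "the series" means these few. Any claim that something is new, unique, unknown or untested is made for them only; others in the source may bear on it.

Compound 1 `CCCCC/C=N/NC(=O)c1ccc(O[C@@H]2O[C@H](CO)[C@@H](O)[C@H](O)[C@H]2O)cc1` gives 11% in a functional assay on MDA-MB-231 cells (Homo sapiens) for inhibition, read by MTT assay, with a stated time of 24 h, tested at 100 uM (a lower number here means less inhibition, a higher number more inhibition at the concentration tested (going by the name of the read-out)), the highest of the three numbers shown, though compound 3 `O=C(N/N=C/c1ccccc1)c1ccc(O[C@@H]2O[C@H](CO)[C@@H](O)[C@H](O)[C@H]2O)cc1` gives 3.56% and the step of a number 7.4 percentage points lower from compound 1 to compound 3 (within the scatter) stays within the scatter, while compound 2 `O=C(N/N=C/C1CCCCC1)c1ccc(O[C@@H]2O[C@H](CO)[C@@H](O)[C@H](O)[C@H]2O)cc1` gives 0.88% and the step of a number 10.1 percentage points lower from compound 1 to compound 2 (beyond the scatter) lies beyond it. Compound 4 `Cc1ccc(/C=N/NC(=O)c2ccc(O[C@@H]3O[C@H](CO)[C@@H](O)[C@H](O)[C@H]3O)cc2)cc1` differs from compound 1 by 4-methylphenyl in place of pentyl on a carbon with a double bond to nitrogen. Within the data shown here, the steps that bear on this change are those putting a ring in place of pentyl, a number 10.1 percentage points lower from compound 1 to compound 2 (beyond the scatter) and a number 7.4 percentage points lower from compound 1 to compound 3 (within the scatter); between the two rings, phenyl in place of cyclohexyl gave a number 2.7 percentage points higher from compound 2 to compound 3 (within the scatter). A small downward step is therefore expected, a number 6 percentage points lower from compound 1 to compound 4 (within the scatter), probably not beyond the scatter. Compound 4 is expected to give 5%, within a range from 0% to 15%.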

Compound 4, a percentage reported as inhibition, at one concentration (the size of the read-out at that concentration, not a potency): 9.28%
Beside the measured number, compound 4's estimate is 4.3 percentage points below it; the range from low to high includes it.
By their numbers in this assay, from the lowest: compounds 2, 3, 4 and 1 (each within the scatter of the next, the first and the last beyond it).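

Here 4-methylphenyl in place of pentyl gives a number 1.7 percentage points lower from compound 1 to compound 4 (within the scatter) and so is not set apart from pentyl at this position. Methyl in place of hydrogen on an aromatic carbon gives a number 5.7 percentage points higher from compound 3 to compound 4 (within the scatter) and 4-methylphenyl in place of cyclohexyl gives a number 8.4 percentage points higher from compound 2 to compound 4 (within the scatter) so compound 4 cannot be ranked against compound 3 or compound 2. Among these compounds, the only step beyond the scatter remains the one from pentyl to cyclohexyl.

On these data alone, whether a longer chain, an amine or a carboxylic acid on this carbon would raise the read-out clear of pentyl stays open. Nothing available explains these numbers.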